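The compounds below may be only part of what the source reports. "The series", "measured", "known", "first", "only" and "open" are said of these compounds alone.

Of the compounds shown here, three built on one shared core have been tested in a functional assay on HEL cells (Homo sapiens); on this read-out higher numbers stand for lower toxicity in this test and lower numbers for higher toxicity in this test. Compound 1 `Cc1cn([C@@H]2O[C@H](CO[Si](C)(C)C(C)(C)C)[C@@]3(OS(=O)(=O)C=C3NCC(=O)O)[C@H]2O[Si](C)(C)C(C)(C)C)c(=O)n(C)c1=O`, which carries a carboxymethyl group on an amine nitrogen, gives 136000 nM. Compound 2 `CCOC(=O)NC(=O)NC1=CS(=O)(=O)O[C@@]12[C@@H](CO[Si](C)(C)C(C)(C)C)O[C@@H](n1cc(C)c(=O)n(C)c1=O)[C@@H]2O[Si](C)(C)C(C)(C)C` gives 14000 nM, and compound 3 `Cc1cn([C@@H]2O[C@H](CO[Si](C)(C)C(C)(C)C)[C@@]3(OS(=O)(=O)C=C3NC(N)=O)[C@H]2O[Si](C)(C)C(C)(C)C)c(=O)n(C)c1=O` gives 11000 nM. Compound 3 is clearly lower only than compound 1, the step of a 12-fold lower number from compound 1 to compound 3 (1.09 log units; beyond the scatter) lying beyond the scatter, while the numbers of compound 2 and compound 3 lie within the scatter of each other, as the step of a 1.3-fold lower number from compound 2 to compound 3 (0.10 log units; within the scatter) shows.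

Compound 4 `Cc1cn([C@@H]2O[C@H](CO[Si](C)(C)C(C)(C)C)[C@@]3(OS(=O)(=O)C=C3NC(=O)c3ccccc3)[C@H]2O[Si](C)(C)C(C)(C)C)c(=O)n(C)c1=O` has not yet been measured. It differs from compound 3 in one place: phenyl in place of amino on a carbonyl carbon. Among the measured compounds shown here, no measured step exchanges amino for phenyl on a carbonyl carbon. The nearest guide is the step of a 1.3-fold lower number from compound 2 to compound 3 (0.10 log units; within the scatter), a change at the same amide-type nitrogen that stayed within the scatter, whereas the step of a 12-fold lower number from compound 1 to compound 3 (1.09 log units; beyond the scatter) shows that a larger rebuilding of this side chain can move the number considerably. A small step, if any, is therefore expected for compound 4, with a 1.1-fold higher number from compound 3 to compound 4 (0.04 log units; within the scatter) as the expected change. Compound 4 is estimated at 12000 nM, within a range from 4000 nM to 40000 nM.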

Compound 4, half-maximal cytotoxic concentration: 9700 nM
Compound 4: middle estimate off by 1.2-fold (0.09 log units), on the high side; measured number inside the range.
By their numbers in this assay, from the lowest: compounds 4, 3 and 2 (each within the scatter of the next); then compound 1.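

In this assay, putting phenyl in place of amino on the carbonyl carbon adds an aromatic ring and removes a hydrogen-bond donor, yet the step stays within the scatter (a 1.1-fold lower number from compound 3 to compound 4 (0.05 log units; within the scatter)). Phenyl in place of (ethoxycarbonyl)amino also stays within the scatter (a 1.4-fold lower number from compound 2 to compound 4 (0.16 log units; within the scatter)), so these three quite different groups on this carbonyl carbon give numbers that cannot be told apart, while compound 1, with carboxymethyl on the amine nitrogen, remains clearly separate (a 14-fold lower number from compound 1 to compound 4 (1.15 log units; beyond the scatter)). No measurement offered here accounts for this picture.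

Still open, going by these compounds, is whether a methyl group, a longer chain or a chlorine-bearing phenyl on this carbonyl carbon would stay equally close. Also open, on these data alone, is whether an ethyl ester in place of the carboxylic acid of compound 1 would keep its number.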